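Swapping bromine for iodine on the fused ring

A few compounds are considered here, and "the series" means these few. Any claim that something is new, unique, unknown or untested is made for them only; others in the source may bear on it.

Measured compounds:
compound 1 `O=c1oc2ccc(Br)cc2c(=O)n1-c1ccc(I)cc1F` — 7900 nM
compound 2 `O=c1oc2ccc(Br)cc2c(=O)n1-c1ccc(Br)cc1F` — 7200 nM

Both compounds were tested in an ADME assay on RAW264.7 cells (Mus musculus) for cytotoxicity, read by MTT assay, with a stated time of 24 h; on this read-out lower numbers stand for higher toxicity in this test and higher numbers for lower toxicity in this test. Compound 1 gives 7900 nM, the highest of the two numbers; its nearest neighbour is compound 2, which gives 7200 nM. Among the measured compounds shown here, the one measured step, a 1.1-fold lower number from compound 1 to compound 2 (0.04 log units; within the scatter), exchanges bromo for iodo on the pendant aromatic ring and lies within the scatter.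

Compound 3 `O=c1oc2ccc(I)cc2c(=O)n1-c1ccc(I)cc1F` is not yet measured. It differs from compound 1 by iodo in place of bromo on an aromatic carbon of a six-membered aromatic ring of carbon only, part of a fused or bridged system of two rings, meta to a fused ring and para to a fused ring. For the measured compounds named here, the only step that bears on this, the same halogen exchange at another place, left this assay unchanged beyond the scatter, so no step beyond the scatter is expected here either. Compound 3 is therefore expected at 7500 nM, between 3500 nM and 16000 nM, a step of a 1.1-fold lower number from compound 1 to compound 3 (0.02 log units; within the scatter).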

Compound 3, half-maximal cytotoxic concentration: 7600 nM
Compound 3: middle estimate off by 1.0-fold (0.01 log units), on the low side; the measured number falls inside the stated range.
By their numbers in this assay, from the lowest: compounds 2, 3 and 1 (each within the scatter of the next).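

In this assay the exchange of bromo for iodo at this place, on the six-membered aromatic ring of carbon only that is part of the fused system, gives a 1.0-fold lower number from compound 1 to compound 3 (0.02 log units; within the scatter) and so shows that this second halogen place also has no step beyond the scatter. The earlier pair spoke only for the pendant ring, whereas the same two halogens have now been exchanged on both rings of these compounds, and neither step lies beyond the scatter. Nothing given here accounts for this result.

As far as these compounds go, these compounds show only bromo and iodo at this place, so it stays open whether an amine, a carboxylic acid or a longer chain there would give a step beyond the scatter. They also leave open whether the same holds for any cell type other than the one tested here.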